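Hydrogen in place of methoxy: compound 2 to compound 3

The source may report more compounds than this note shows. Statements on the series, on what has been measured and on what is new or still open speak of the compounds shown alone.

In a functional assay on THP-1 cells (Homo sapiens) for inhibition, read by sulforhodamine B assay, with a stated time of 48 h, tested at 50 uM (a lower number here means less inhibition of growth, a higher number more inhibition of growth at the concentration tested), compound 1 (`COc1cc(/C=C/C(=O)/C=C/c2cccs2)ccc1OCc1cn(CCCCCOc2cc(=O)oc3ccccc23)nn1`) gives 34% and compound 2 (`COc1ccc(/C=C/C(=O)/C=C/c2ccc(OCc3cn(CCCCCOc4cc(=O)oc5ccccc45)nn3)c(OC)c2)cc1`) gives 39%. For the measured compounds named here, these two numbers lie within the scatter of each other, so compound 2 stands level with its only measured neighbour. Compound 3 (`COc1cc(/C=C/C(=O)/C=C/c2ccccc2)ccc1OCc1cn(CCCCCOc2cc(=O)oc3ccccc23)nn1`) differs from compound 2 by hydrogen in place of methoxy on an aromatic carbon, with hydrogen in place of methoxy on an aromatic carbon, so that 4-methoxyphenyl becomes phenyl. Going by the values given here, one measured step bears on this: a number 5 percentage points higher from compound 1 to compound 2 (within the scatter), which exchanges thiophen-2-yl for the same 4-methoxyphenyl group. Among the compounds with values here, no measured pair isolates the methoxy group itself, so this evidence is indirect. No step beyond the scatter is therefore expected in this assay. For compound 3 the expected value is 36%, within an estimated range of 24% to 48%. The expected change is a number 3 percentage points lower from compound 2 to compound 3 (within the scatter).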

Compound 3, percent growth inhibition at one concentration: 26%
Compound 3: middle estimate off by 10 percentage points, on the high side; the range from low to high includes it.
By their numbers in this assay, from the lowest: compounds 3, 1 and 2 (each within the scatter of the next, the first and the last beyond it).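

In this assay, for the compounds shown here, the step of a number 13 percentage points lower from compound 2 to compound 3 (beyond the scatter) gives the first direct reading of the methoxy group on the 4-methoxyphenyl group: the change from 4-methoxyphenyl to phenyl lowers growth inhibition modestly, beyond the scatter. Going by these compounds alone, the other new step, a number 8 percentage points lower from compound 1 to compound 3 (within the scatter), stays within the scatter, so thiophen-2-yl is not separated from phenyl here, nor from 4-methoxyphenyl, and only the pair differing by the methoxy group is separated. Nothing shown here accounts for the size of this step.

Going by these compounds, it remains open how a hydroxy, chloro or dimethylamino group would read at this same place. On these data alone, it also remains open whether the methoxy step would hold with a longer or shorter chain between the triazole and the rest of the core.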